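The source may report more compounds than this note shows. Statements on the series, on what has been measured and on what is new or still open speak of the compounds shown alone.

Of the compounds shown here, three of one family have been tested in an assay on HEK293 cells for agonist activity at transient receptor potential cation channel subfamily M member 8 (Homo sapiens), read by fluorescence and calcium flux, with a stated time of 15 min; on this read-out higher numbers stand for an effect only at larger amounts of compound and lower numbers for an effect already at smaller amounts. Compound 1 `CCCc1ccc(OCC(=O)N(CC)Cc2cccs2)cc1` gives 1810 nM. Compound 2 `COc1ccc(OCC(=O)N(Cc2cccs2)c2ccn[nH]2)cc1` gives 3.7 nM. Compound 3 `Cc1ccc(OCC(=O)N(Cc2cccs2)c2ccncc2)cc1` gives 52 nM. On these three numbers compound 3 stands second highest: its gap to compound 2, the nearest number, and its gap to compound 1, the furthest, both lie beyond the usual scatter of this measurement.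

Compound 4 `Cc1ccc(OCC(=O)N(Cc2cccs2)C2CC2)cc1` has not yet been measured. It differs from compound 3 in one place: cyclopropyl in place of pyridin-4-yl on an amide-type nitrogen. For the measured compounds named here, no pair of measured compounds shows exactly this kind of exchange, so what comes next is an expectation rather than a reading. A step from compound 3 to compound 4 that raises the number beyond the scatter is expected, because compound 1 with a saturated chain carbon on the amide-type nitrogen gives 1810 nM while the two aromatic groups on that nitrogen give lower numbers. The expected step is a 9.6-fold higher number from compound 3 to compound 4 (0.98 log units; beyond the scatter). For compound 4 in this assay a value of about 500 nM is estimated, within a range from 100 nM to 3000 nM.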

Compound 4, half-maximal effective concentration: 8 nM
Estimate against measurement, compound 4: 63-fold (1.80 log units) above; the whole stated range lies above it.
By their numbers in this assay, from the lowest: compound 2; then compound 4; then compound 3; then compound 1.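

In this assay, putting cyclopropyl in place of pyridin-4-yl on the amide-type nitrogen gives a 6.5-fold lower number from compound 3 to compound 4 (0.81 log units; beyond the scatter), so the effect appears at smaller amounts of compound. At this position in this pair, then, a six-membered aromatic ring with a hetero atom is not needed for a low number: a three-membered non-aromatic ring of carbon only, with fewer heavy atoms and no hydrogen-bond acceptor, gives a lower one. Nothing available explains why the number falls with this exchange.

On these data alone, this single exchange alters ring size, aromatic character and the ring nitrogen all at once, and which of these matters stays open. A phenyl, a cyclobutyl or an isopropyl group on the same amide-type nitrogen would help tell them apart.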